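Cytotoxicity notes on the chlorocoumarin sulfonamide imines

This account rests on a few compounds, and the source may have more. Where it says the series, first, only, none or still open, it means among the compounds named here.

Compound 1 `NS(=O)(=O)c1ccc(/N=C/c2c(Cl)c3ccccc3oc2=O)cc1` and compound 2 `Cc1ccc2oc(=O)c(/C=N/c3ccc(S(N)(=O)=O)cc3)c(Cl)c2c1` share one core and differ by a single group. In an ADME assay on cells (Macrophage, Homo sapiens) for cytotoxicity, read by microscopy and CCK-8 assay, with a stated time of 48 h (a higher number here means that more compound is tolerated, a lower number that less compound is tolerated), compound 1 gives 580 nM, and in this assay compound 2 gives 1200 nM. Among the compounds with values here, the one change measured so far, a 2.1-fold higher number from compound 1 to compound 2 (0.32 log units; beyond the scatter), is methyl in place of hydrogen on an aromatic carbon. Within the data shown here, on the two numbers available, compound 2 stands highest, with compound 1 as its only neighbour.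

Compound 3 `Cc1ccc2oc(=O)c(/C=N/c3ccc(S(=O)(=O)Nc4nccc(C)n4)cc3)c(Cl)c2c1` is not yet measured. It differs from compound 2 by 4-methylpyrimidin-2-yl in place of hydrogen on a sulfonamide nitrogen. Among the measured compounds shown here, no measured step touches the sulfonamide nitrogen; the only known step concerns an aromatic carbon and so does not bear on this change. With nothing to point either way, a step from compound 2 to compound 3 of no change at the digits printed from compound 2 to compound 3 (within the scatter) is expected, that is, none beyond the scatter. Compound 3 is therefore estimated at 1200 nM in this assay, within 400 nM to 3600 nM.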

Compound 3, minimum cytotoxic concentration: 560 nM
Compound 3: middle estimate off by 2.1-fold (0.33 log units), on the high side; the range from low to high includes it.
By their numbers in this assay, from the lowest: compounds 3 and 1 (each within the scatter of the next); then compound 2.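

The sulfonamide nitrogen, untouched by the earlier step on the aromatic carbon, is also a position where a change registers in this assay (a 2.1-fold lower number from compound 2 to compound 3 (0.33 log units; beyond the scatter)). Replacing hydrogen with 4-methylpyrimidin-2-yl, that is, amino to (4-methylpyrimidin-2-yl)amino, means that less compound is tolerated, in a modest step that lies beyond the scatter. No measured evidence on the origin of this step is available.

The compounds shown do not separate the effect of the 4-methylpyrimidin-2-yl group from that of any substituent on this nitrogen, since a plain methyl, an acetyl or an unmethylated pyrimidin-2-yl is not among them. They also leave open whether the same step would appear on the core of compound 1, which lacks the aromatic methyl.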